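Trifluoromethoxy for Isopropoxy: Cytotoxicity Stays at the Limit

This account rests on a few compounds, and the source may have more. Where it says the series, first, only, none or still open, it means among the compounds named here.

Compound 1 `CCOC(=O)c1c(-c2cccc(OC(C)C)c2)[nH]c2cc(OC)ccc2c1=O` gives > 21500 nM in an ADME assay on HepG2 cells (Homo sapiens) for cytotoxicity, read by luminescence, with a stated time of 72 h (a higher number here means that more compound is needed for the effect, a lower number that less compound is needed), which is a limit of the assay and not a number.
Compound 2 `CCOC(=O)c1c(-c2cccc(OC(F)(F)F)c2)[nH]c2cc(OC)ccc2c1=O` gives > 21500 nM in this assay, again a limit.
Compound 3 `CCOC(=O)c1c(-c2cccc(OC)c2)[nH]c2cc(OC(C)C)ccc2c1=O` gives > 21500 nM in this assay, also a limit.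

None of the three measured compounds produced a half-maximal effect within the tested range, so each of them carries only a limit. Compound 2 differs from compound 1 by a single change, (trifluoromethyl in place of isopropyl on an oxygen on an aromatic ring). The step that the two limits leave unreadable from compound 1 to compound 2 cannot be read because both ends of it sit at the limit described by the limit of > 21500 nM in this assay, at which 3 of the 3 values shown sit. Compound 3 is made of the same atoms as compound 1, joined differently; the difference between the two cores is not broken down here.

Compound 4 `CCOC(=O)c1c(-c2cccc(OC)c2)[nH]c2cc(OC(F)(F)F)ccc2c1=O` has not yet been measured. Within the data shown here, it differs from compound 3 by trifluoromethyl in place of isopropyl on an oxygen on an aromatic ring, the same change as the one from compound 1 to compound 2, at a place described in identical words. Among the measured compounds shown here, that change left the read-out at a limit at both ends, and compound 3 itself sits at a limit, so no measured step suggests that the change brings the effect into the readable range.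

Compound 4 is therefore expected to sit around 30000 nM, most probably reported again only as a limit, with an expected spread from 15000 nM to 100000 nM. This expectation corresponds to a step that the limit leaves unreadable from compound 3 to compound 4, which is estimated to stay within the limit rather than become a readable number.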

Compound 4, half-maximal effective concentration: > 21500 nM
Compound 4 was reported as a limit; the forecaster's own chance of this, stated with the estimate: 85%; the middle value does not contradict the limit.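

The step from compound 3 to compound 4 cannot be read, just like the earlier one from compound 1 to compound 2, because each of these compounds gives only a limit of the assay and not a number: the limit of > 21500 nM in this assay, at which 4 of the 4 values shown sit.

The compounds shown leave open whether trifluoromethyl in place of isopropyl on an oxygen on an aromatic ring changes the read-out in this assay at all.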